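Trimming the chain from compound 2 to compound 3

The source may hold more compounds than are shown below. What is called first, only, known or untested is meant among the compounds shown, and "the series" means these compounds.

- compound 1 `Cn1cc(C2=C(c3nn(CCCn4cccc4)c4ncccc34)C(=O)NC2=O)c2ccccc21`: 21600 nM
- compound 2 `Cn1cc(C2=C(c3nn(CCCCn4ccnc4)c4ncccc34)C(=O)NC2=O)c2ccccc21`: 31800 nM

These compounds share a core and differ in the chain that carries a ring at its end. Within the data shown here, in a functional assay on K562 cells (Homo sapiens) for antiproliferative activity, read by MTT assay, with a stated time of 48 h (a higher number here means a weaker inhibitor, a lower number a stronger inhibitor), compound 2 gives 31800 nM, within the scatter of compound 1, the only other compound measured. Compound 3 `Cn1cc(C2=C(c3nn(CCn4ccnc4)c4ncccc34)C(=O)NC2=O)c2ccccc21` has a shorter chain: 1H-imidazol-1-yl in place of 2-(1H-imidazol-1-yl)ethyl on a saturated chain carbon, two bonds along the chain from an aromatic nitrogen. Put simply, 4-(1H-imidazol-1-yl)butyl becomes 2-(1H-imidazol-1-yl)ethyl.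

Among the measured compounds shown here, only one measured step bears on this change: a 1.5-fold higher number from compound 1 to compound 2 (0.17 log units; within the scatter). It altered the chain and the end ring together, and it stayed small. For the measured compounds named here, no measured compound carries the shorter chain, so this evidence is thin. No change beyond the scatter is therefore expected in this assay. The expected step is a 1.2-fold lower number from compound 2 to compound 3 (0.09 log units; within the scatter). For compound 3 the estimate is 26000 nM, with an expected range of 11000 nM to 60000 nM.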

Compound 3, half-maximal inhibitory concentration: > 100000 nM
Compound 3 gave a limit, no number; the forecaster's own chance of this, stated with the estimate: 10%; middle value at least 3.8-fold (0.58 log units) from the limit.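

The two-carbon chain shows something that compound 1 and compound 2 could not: in this assay those two stayed within the scatter of each other, whereas the end of the chain now makes a clear difference. The reading for compound 3 is a limit of the assay and not a number: the limit of > 100000 nM in this assay, at which 1 of the 3 values shown sits. Even so, the change shows as an at least 3.1-fold higher number from compound 2 to compound 3 (0.49 log units; beyond the scatter) and as an at least 4.6-fold higher number from compound 1 to compound 3 (0.66 log units; beyond the scatter), although the second step changes the end ring as well as the chain.

The true size of both steps remains unknown, and with so few compounds the shown trend rests on compound 3 alone. From the compounds shown here alone, it remains open how a 3-(1H-imidazol-1-yl)propyl chain, a longer chain, or an amine in place of the end ring would read in this assay.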